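Chain-end amino versus hydroxy in a spiro-amide series

The source may report more compounds than this note shows. Statements on the series, on what has been measured and on what is new or still open speak of the compounds shown alone.

Compound 1 `CC(C)(C)c1ccc(C(=O)N2CCC3(CC2)C(=O)N(CC(=O)NCCCN)CN3c2ccccc2)cc1` carries the shortest chain; in an assay on HEK293 cells for displacement of a labelled ligand from NPC1-like intracellular cholesterol transporter 1 (Homo sapiens) (on this read-out lower numbers stand for stronger inhibition and higher numbers for weaker inhibition), compound 1 gives 4200 nM. Compound 2 `CC(C)(C)c1ccc(C(=O)N2CCC3(CC2)C(=O)N(CC(=O)NCCCCO)CN3c2ccccc2)cc1` differs by hydroxymethyl in place of amino on a saturated chain carbon, three bonds along the chain from an amide-type nitrogen, and compound 2 gives 19200 nM; the step is a 4.6-fold higher number from compound 1 to compound 2 (0.66 log units; beyond the scatter). Compound 3 `CC(C)(C)c1ccc(C(=O)N2CCC3(CC2)C(=O)N(CC(=O)NCCCCN)CN3c2ccccc2)cc1` differs from compound 1 by aminomethyl in place of amino on a saturated chain carbon, three bonds along the chain from an amide-type nitrogen, and compound 3 gives 14500 nM; the step is a 3.5-fold higher number from compound 1 to compound 3 (0.54 log units; beyond the scatter). Between compound 2 and compound 3 the step is a 1.3-fold lower number from compound 2 to compound 3 (0.12 log units; within the scatter), so amino and hydroxy at that distance cannot be told apart here.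

Compound 4 `CC(C)(C)c1ccc(C(=O)N2CCC3(CC2)C(=O)N(CC(=O)NCCCCCO)CN3c2ccccc2)cc1` has not yet been measured in this assay. It differs from compound 3 by hydroxymethyl in place of amino on a saturated chain carbon, four bonds along the chain from an amide-type nitrogen. This is the same kind of change as that from compound 1 to compound 2, but not the same: there the place was on a saturated chain carbon, three bonds along the chain from an amide-type nitrogen, whereas here it is on a saturated chain carbon, four bonds along the chain from an amide-type nitrogen. The two cores differ by aminomethyl in place of amino on a saturated chain carbon, three bonds along the chain from an amide-type nitrogen.

For compound 4 a step of a 2.8-fold higher number from compound 3 to compound 4 (0.44 log units; beyond the scatter) is expected, set between the earlier step of a 4.6-fold higher number from compound 1 to compound 2 (0.66 log units; beyond the scatter) and the smaller gap a 1.3-fold lower number from compound 2 to compound 3 (0.12 log units; within the scatter). Among the compounds with values here, compound 4 is estimated at 40000 nM, with a range from 15000 nM to 110000 nM; with only two comparisons behind it, the uncertainty is wide.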

Compound 4, half-maximal inhibitory concentration: 9400 nM
The estimate for compound 4 lay 4.3-fold (0.63 log units) above the measured number; measured number below the stated range.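

In this assay the exchange of amino for hydroxymethyl does not transfer as a fixed step from the core of compound 1 to the core of compound 3: the same change on two cores in this assay, a 4.6-fold higher number (0.66 log units; beyond the scatter) from compound 1 to compound 2 and a 1.5-fold lower number (0.19 log units; within the scatter) from compound 3 to compound 4, 7.1-fold (0.85 log units) apart, beyond the scatter of two such steps

On the longer chain the step is a 1.5-fold lower number from compound 3 to compound 4 (0.19 log units; within the scatter) and the two chain ends cannot be told apart, so the penalty seen on the shorter chain should not be assumed for other cores in this series. This is a single comparison of two steps, and it shows neither the reason for the gap nor how the step would behave on any other chain. Among the hydroxy-ended compounds, the further step is a 2.0-fold lower number from compound 2 to compound 4 (0.31 log units; beyond the scatter) and the comparison with the shortest amine is a 2.2-fold higher number from compound 1 to compound 4 (0.35 log units; beyond the scatter), which leaves compound 1 with the lowest number of the four, although these modest steps do not establish a trend with chain length.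

The compounds shown leave open whether a hydroxy end on a chain as short as that of compound 1 would match the amine there, which would help separate the effect of chain length from that of the end group. Also open, on these data alone, is how a shorter amine, a longer chain or a carboxylic acid at the chain end would read in this assay.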